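A few compounds are considered here, and "the series" means these few. Any claim that something is new, unique, unknown or untested is made for them only; others in the source may bear on it.

Going by the values given here, in a functional assay on U-87MG ATCC cells for antiproliferative activity against U-87 MG (Homo sapiens), read by MTT assay, with a stated time of 48 h (a lower number here means a stronger inhibitor, a higher number a weaker inhibitor), compound 2 (`C/C(=C\CC/C(C)=C/CC[C@@H]1[C@@]2(C)CCC(=O)C(C)(C)[C@H]2CC[C@@]1(C)O)CC/C=C(\C)C(=O)OCc1cn(-c2cccc([N+](=O)[O-])c2)nn1`) gives 134000 nM, the only exact number in this small series. Compound 1 (`C/C(=C\CC/C(C)=C/CC[C@@H]1[C@@]2(C)CCC(=O)C(C)(C)[C@H]2CC[C@@]1(C)O)CC/C=C(\C)C(=O)OCc1cn(-c2ccc(F)cc2)nn1`) reads > 150000 nM, which is a limit of the assay and not a number. Among the compounds with values here, the one measured step that bears on the next compound is an at least 1.1-fold lower number from compound 1 to compound 2 (0.04 log units; that floor lies within the scatter), with 3-nitrophenyl in place of 4-fluorophenyl on an aromatic nitrogen. That step is known only as a floor. Compound 3 (`C/C(=C\CC/C(C)=C/CC[C@@H]1[C@@]2(C)CCC(=O)C(C)(C)[C@H]2CC[C@@]1(C)O)CC/C=C(\C)C(=O)OCc1cn(-c2cccc(Br)c2)nn1`) keeps the shared core and carries bromo in place of nitro on an aromatic carbon, meta to a large group: bromo in place of nitro on an aromatic carbon. With only that floor from an at least 1.1-fold lower number from compound 1 to compound 2 (0.04 log units; that floor lies within the scatter) to go on, no step beyond the scatter is expected in this assay, and a reading at the limit would not be a surprise. The estimate means an expected 1.1-fold lower number from compound 2 to compound 3 (0.03 log units; within the scatter). Compound 3 is expected at 125000 nM, within an estimated range from 60000 nM to 200000 nM.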

Compound 3, half-maximal inhibitory concentration: 8750000 nM
Compound 3: middle estimate off by 70-fold (1.85 log units), on the low side; measured number above the stated range.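

In this assay, the group on this aromatic carbon, meta to a large group, proves to matter: bromo in place of nitro gives a 65-fold higher number from compound 2 to compound 3 (1.81 log units; beyond the scatter). Going by these compounds alone, the earlier step was known only as a floor within the scatter, so this is the first step that reads as a number beyond the scatter, and in this pair compound 2 is the stronger inhibitor. The step that links compound 1 with compound 3 cannot be read, since the value of compound 1 is a limit of the assay and not a number: the limit of > 150000 nM in this assay, at which 1 of the 3 values shown sits.

The compounds shown do not tell whether nitro supports the reading of compound 2 or bromo weakens that of compound 3. On these data alone, how chloro, methoxy or an amine on the same carbon would read also remains open.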